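Swapping an aromatic ring for a hexyl chain

The compounds below may be only part of what the source reports. "The series", "measured", "known", "first", "only" and "open" are said of these compounds alone.

In an assay on cells for agonist activity at ecdysone receptor (Bombyx mori), read by a luciferase reporter, with a stated time of 24 h (a higher number here means that more compound is needed for the effect, a lower number that less compound is needed), the three measured compounds give:
Compound 1 `Cc1ccccc1C(=O)NN(C(=O)c1ccccc1Cl)C(C)(C)C`: 72.4 nM
Compound 2 `CC(C)(C)N(NC(=O)c1ccc(F)cc1)C(=O)c1ccccc1Cl`: 389 nM
Compound 3 `COc1ccc(C(=O)NN(C(=O)c2ccccc2Cl)C(C)(C)C)cc1`: 51.3 nM

For the measured compounds named here, compound 3 shows the lowest of these three numbers, though only the step from compound 2 a 7.6-fold lower number from compound 2 to compound 3 (0.88 log units; beyond the scatter) lies beyond the scatter; the step from compound 1 a 1.4-fold lower number from compound 1 to compound 3 (0.15 log units; within the scatter) is within it. Compound 4 `CCCCCCC(=O)NN(C(=O)c1ccccc1Cl)C(C)(C)C` differs from compound 3 by hexyl in place of 4-methoxyphenyl on a carbonyl carbon. Every measured step changes this same group: a 5.4-fold higher number from compound 1 to compound 2 (0.73 log units; beyond the scatter) and a 7.6-fold lower number from compound 2 to compound 3 (0.88 log units; beyond the scatter) were modest, while a 1.4-fold lower number from compound 1 to compound 3 (0.15 log units; within the scatter) was within the scatter. None of them removes the ring, so the evidence is thin. A modest rise a 2.9-fold higher number from compound 3 to compound 4 (0.47 log units; beyond the scatter) is expected, and compound 4 is estimated at 150 nM, within 40 nM to 600 nM.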

Compound 4, half-maximal effective concentration: 741 nM
Compound 4: the middle estimate sits 4.9-fold (0.69 log units) below what was measured; measured number outside the range, above it.
By their numbers in this assay, from the lowest: compounds 3 and 1 (each within the scatter of the next); then compounds 2 and 4 (each within the scatter of the next).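

Here the ring on this carbonyl carbon is gone for the first time, and the outcome depends on which ring hexyl replaces: the steps are large for a 14-fold higher number from compound 3 to compound 4 (1.16 log units; beyond the scatter) and a 10-fold higher number from compound 1 to compound 4 (1.01 log units; beyond the scatter), but small for a 1.9-fold higher number from compound 2 to compound 4 (0.28 log units; within the scatter). An aromatic ring here is therefore not enough for a low number, since compound 2 carries one and still sits within the scatter of compound 4. No measurement shown explains this difference between the rings. Still open, on these data alone, is how a saturated ring such as cyclohexyl, a shorter chain such as butyl, or a hexyl chain ending in an amine would compare.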